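The source may report more compounds than this note shows. Statements on the series, on what has been measured and on what is new or still open speak of the compounds shown alone.

Measured in a functional assay on MGC-803 cells (Homo sapiens) for inhibition, read by sulforhodamine B assay; on this read-out higher numbers stand for weaker inhibition and lower numbers for stronger inhibition:
- Compound 1 `O=C1C=C(N2CCC2)C(=O)c2c1nc1n2[C@H]2OC[C@@H](O)[C@H]2OC1`: > 16000 nM, a limit of the assay
- Compound 2 `CCc1ccc(NC2=CC(=O)c3nc4n(c3C2=O)[C@H]2OC[C@@H](O)[C@H]2OC4)cc1`: 1290 nM
- Compound 3 `O=C1C=C(NC2CCCC2)C(=O)c2c1nc1n2[C@H]2OC[C@@H](O)[C@H]2OC1`: > 8000 nM, a limit of the assay

Compound 3 has no exact value: its > 8000 nM is a limit and not a number. Compound 4 `Cc1ccc(NC2=CC(=O)c3nc4n(c3C2=O)[C@H]2OC[C@@H](O)[C@H]2OC4)cc1C` keeps the shared core and changes one group, with 3,4-dimethylphenyl in place of cyclopentyl on an amine nitrogen.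

The closest evidence is an at least 6.2-fold higher number from compound 2 to compound 3 (0.79 log units; beyond the scatter), a swap of 4-ethylphenyl for cyclopentyl that runs the opposite way to the change here. A second measured step points the same way: an at least 12-fold lower number from compound 1 to compound 2 (1.09 log units; beyond the scatter), with (4-ethylphenyl)amino in place of azetidin-1-yl. Only compound 2 carries an aromatic ring on that nitrogen, so this rests on a single example. The step that the two limits leave unreadable from compound 1 to compound 3 cannot be read.

In this assay the expected change is an at least 5.3-fold lower number from compound 3 to compound 4 (0.72 log units; beyond the scatter), toward stronger inhibition and beyond the scatter. The estimate for compound 4 is 1500 nM, with an expected range from 600 nM to 4000 nM.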

Compound 4, half-maximal inhibitory concentration: 860 nM
Estimate against measurement, compound 4: 1.7-fold (0.24 log units) above; the measured number falls inside the stated range.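

A second aromatic group on the amine nitrogen now supports what had rested on compound 2 alone: in this assay, 3,4-dimethylphenyl in place of cyclopentyl gives an at least 9.3-fold lower number from compound 3 to compound 4 (0.96 log units; beyond the scatter), and (3,4-dimethylphenyl)amino in place of azetidin-1-yl gives an at least 18-fold lower number from compound 1 to compound 4 (1.26 log units; beyond the scatter). Compound 1 and compound 3 each stand at a limit of the assay and not at a number, which makes those two steps bounds only. Among the aromatic groups, 3,4-dimethylphenyl in place of 4-ethylphenyl gives a 1.5-fold lower number from compound 2 to compound 4 (0.18 log units; within the scatter), so these two groups cannot be told apart here.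

Still open, going by these compounds, is how a plain phenyl ring, or one carrying a methoxy group or a chlorine atom, would read on this nitrogen. Also open, on these data alone, is how a benzyl group would read in the same place.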